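Removing a chloro group: expected lipophilicity of compound 4

The source may report more compounds than this note shows. Statements on the series, on what has been measured and on what is new or still open speak of the compounds shown alone.

Measured compounds:
- compound 1 `O=C1N=C(N2CCOCC2)CN1Cc1ccccc1Cl`: 1
- compound 2 `O=C1N=C(N2CCOCC2)CN1c1ccc(Cl)c(Cl)c1`: 1.9
- compound 3 `O=C1N=C(N2CCOCC2)CN1Cc1c(Cl)cccc1Cl`: 1.3

Of the compounds shown here, three have been measured in a physicochemical assay for lipophilicity; on this read-out lower numbers stand for lower lipophilicity and higher numbers for higher lipophilicity. Compound 1 `O=C1N=C(N2CCOCC2)CN1Cc1ccccc1Cl` and compound 3 `O=C1N=C(N2CCOCC2)CN1Cc1c(Cl)cccc1Cl` share one core, and compound 2 `O=C1N=C(N2CCOCC2)CN1c1ccc(Cl)c(Cl)c1` has a different core; the difference between the two cores is not broken down here. In this assay compound 2 gives 1.9, the highest of the three numbers, and its distance to compound 3 and to compound 1 lies beyond the scatter in each case.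

One structural change has been seen once so far. Going from compound 3 to compound 1, the change is hydrogen in place of chloro on an aromatic carbon, and the measured step was a number 0.30 log units lower from compound 3 to compound 1 (within the scatter).

Compound 4 `O=C1N=C(N2CCOCC2)CN1c1cccc(Cl)c1` has not yet been measured in this assay. Going from compound 2 to compound 4, the change is hydrogen in place of chloro on an aromatic carbon. For the measured compounds named here, this is the same kind of change as the one from compound 3 to compound 1, but not the same: in the earlier case the place was ortho to a large group and meta to a chloro group, whereas here it is ortho to a chloro group and para to a large group.

The step from compound 2 to compound 4 is expected to be about a number 0.50 log units lower from compound 2 to compound 4 (beyond the scatter), somewhat larger than the earlier one, because a number 0.30 log units lower from compound 3 to compound 1 (within the scatter) was small and sat within the scatter, while a lost chlorine usually lowers this read-out. Compound 4 is thus estimated at 1.4, with a likely range from 1 to 1.8.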

Compound 4, partition coefficient: 1.3
Estimate against measurement, compound 4: 0.10 log units above, and the stated range covers the measured number.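

In this assay, hydrogen in place of chloro on an aromatic carbon has now been read on two cores, and the step is a number 0.30 log units lower from compound 3 to compound 1 (within the scatter) on one and a number 0.60 log units lower from compound 2 to compound 4 (beyond the scatter) on the other, so the numbers point the same way, though only the second step stands clear of the scatter. Two steps are too few to make a rule for the series, and they differ in more than the core: here the chloro group that leaves sits ortho to a chloro group and para to a large group, while in the earlier step it sat in another place on the ring, so the effect of the core cannot be separated from the effect of the place. Nothing shown here explains the size of either step.

The compounds shown leave open what this assay would give for a ring with no chloro group at all on either core. They also leave open how a fluoro, methyl or methoxy group would compare with chloro or hydrogen on these same carbons, and whether any such change would carry from one core to the other.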